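Moving Away from 4-methylpiperazin-1-yl in a Small Series

This account rests on a few compounds, and the source may have more. Where it says the series, first, only, none or still open, it means among the compounds named here.

Compound 1 `CCNC(=O)c1nnn(-c2cc(C(C)C)c(O)cc2O)c1-c1ccc(CN2CCCC2)cc1` gives 3 nM
Compound 2 `CCNC(=O)c1nnn(-c2cc(C(C)C)c(O)cc2O)c1-c1ccc(CN(CC)CC)cc1` gives 11 nM
Compound 3 `CCNC(=O)c1nnn(-c2cc(C(C)C)c(O)cc2O)c1-c1ccc(CN2CCN(C)CC2)cc1` gives 47 nM

In a functional assay on NCI-H460 cells (Homo sapiens) for inhibition, read by sulforhodamine B assay, with a stated time of 72 h (on this read-out lower numbers stand for stronger inhibition and higher numbers for weaker inhibition), compound 3 stands at 47 nM and so has the highest of the three numbers. Its nearest neighbour is compound 2 and its furthest is compound 1.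

The next compound is compound 4 `CCNC(=O)c1nnn(-c2cc(C(C)C)c(O)cc2O)c1-c1ccc(CN2CCC(N(C)C)CC2)cc1` and it differs from compound 3 by one change: 4-(dimethylamino)piperidin-1-yl in place of 4-methylpiperazin-1-yl on a saturated chain carbon bound to an aromatic carbon with 4-(dimethylamino)piperidin-1-yl in place of 4-methylpiperazin-1-yl on a saturated chain carbon bound to an aromatic carbon.

For the measured compounds named here, two measured steps bear on this, since both swapped the group at that same place and both ended on 4-methylpiperazin-1-yl. They are a 4.3-fold higher number from compound 2 to compound 3 (0.63 log units; beyond the scatter) as the modest one and a 16-fold higher number from compound 1 to compound 3 (1.19 log units; beyond the scatter) as the large one. Going by the values given here, no measured compound carries 4-(dimethylamino)piperidin-1-yl, so the evidence is indirect. Leaving 4-methylpiperazin-1-yl is therefore expected to bring a modest move to a lower number, closer in size to the smaller of those two steps. The expected move is a 2.6-fold lower number from compound 3 to compound 4 (0.42 log units; beyond the scatter) in this assay and it remains uncertain. Compound 4 is estimated at 18 nM within an expected range of 5 nM to 60 nM in this read-out.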

Compound 4, half-maximal inhibitory concentration: 120 nM
Compound 4: middle estimate off by 6.7-fold (0.82 log units), on the low side; the whole stated range lies below it.
By their numbers in this assay, from the lowest: compound 1; then compound 2; then compound 3; then compound 4.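

In this assay, the move is a 2.6-fold higher number from compound 3 to compound 4 (0.41 log units; beyond the scatter), so leaving 4-methylpiperazin-1-yl at this place, on a saturated chain carbon bound to an aromatic carbon, does not by itself bring a lower number; here the group with more heavy atoms and a single ring nitrogen sits higher. The distance to the two lowest members grows to an 11-fold higher number from compound 2 to compound 4 (1.04 log units; beyond the scatter) and to a 40-fold higher number from compound 1 to compound 4 (1.60 log units; beyond the scatter), so the position spans a wider range than the first three compounds showed. The groups with a second nitrogen, in compound 3 and compound 4, now both stand above the groups of compound 1 and compound 2, and none of the four goes against this, though nothing measured alongside these numbers accounts for it.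

The compounds shown leave open whether the number follows the second nitrogen or the size of the group, as the two change together across this set. Plain piperidin-1-yl would hold the ring while dropping the second nitrogen, morpholin-4-yl would put an oxygen in its place, and dimethylamino would test the low end of the open-chain amines.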